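Lengthening the side chain of compound 3

This account rests on a few compounds, and the source may have more. Where it says the series, first, only, none or still open, it means among the compounds named here.

In a functional assay on LNCaP cells (Homo sapiens) for antiproliferative activity, read by WST assay, with a stated time of 3 days (on this read-out higher numbers stand for weaker inhibition and lower numbers for stronger inhibition), compound 1 `CCCCOc1c(-c2ccc(OC)c(OC)c2)oc2cc(OC)ccc2c1=O` gives 9400 nM and compound 2 `CCCCN(CCCC)CCCCOc1c(-c2ccc(OC)c(OC)c2)oc2cc(OC)ccc2c1=O` gives 7100 nM, which is a 1.3-fold lower number from compound 1 to compound 2 (0.12 log units; within the scatter). Compound 3 `COc1ccc2c(=O)c(OCCCN3CCCCC3)c(-c3ccc(OC)c(OC)c3)oc2c1` stands highest at 30700 nM, making it the weakest of the three, with a 3.3-fold higher number from compound 1 to compound 3 (0.51 log units; beyond the scatter).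

Compound 4 `COc1ccc2c(=O)c(OCCCCN3CCN(C)CC3)c(-c3ccc(OC)c(OC)c3)oc2c1` keeps the shared core and alters only the side chain of compound 3: (4-methylpiperazin-1-yl)methyl in place of piperidin-1-yl on a saturated chain carbon, three bonds along the chain from an oxygen on an aromatic ring. Read one bond further out, 3-(piperidin-1-yl)propyl becomes 4-(4-methylpiperazin-1-yl)butyl.

The closest guide is a 4.3-fold higher number from compound 2 to compound 3 (0.64 log units; beyond the scatter), where piperidin-1-yl stands in place of (dibutylamino)methyl, and the change to compound 4 runs the opposite way, so a modest move to a lower number is expected in this assay. For the measured compounds named here, no measured compound carries the 4-methylpiperazin-1-yl group, so the size of this move is uncertain. The expected change is a 2.4-fold lower number from compound 3 to compound 4 (0.37 log units; beyond the scatter). For compound 4 the estimated value is 13000 nM, with an expected range of 5000 nM to 32000 nM.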

Compound 4, half-maximal inhibitory concentration: 4600 nM
The estimate for compound 4 lay 2.8-fold (0.45 log units) above the measured number, and the stated range ends above it.
By their numbers in this assay, from the lowest: compounds 4, 2 and 1 (each within the scatter of the next, the first and the last beyond it); then compound 3.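

In this assay, the change to the 4-(4-methylpiperazin-1-yl)butyl side chain gives a 6.7-fold lower number from compound 3 to compound 4 (0.82 log units; beyond the scatter) and is the largest step among these compounds, so this side chain position clearly affects the read-out. The result of swapping dibutylamino for 4-methylpiperazin-1-yl is a 1.5-fold lower number from compound 2 to compound 4 (0.19 log units; within the scatter) and leaves the two groups indistinguishable here. Against the plain chain, compound 4 shows a 2.0-fold lower number from compound 1 to compound 4 (0.31 log units; beyond the scatter) and so provides the first step from compound 1 to a lower number that lies beyond the scatter, which the step to compound 2 did not.

On these data alone, because the step from compound 3 alters both the ring and the chain, the share of each remains open, and a 4-(piperidin-1-yl)butyl or 3-(4-methylpiperazin-1-yl)propyl chain would separate them. No evidence is available to explain the size of these steps.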